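A few compounds are considered here, and "the series" means these few. Any claim that something is new, unique, unknown or untested is made for them only; others in the source may bear on it.

Compound 1 `COc1cc(/C=C/c2c[nH]c3ccccc23)cc(OC)c1OC`: 3230 nM
Compound 2 `COc1cc(/C=C\c2c[nH]c3ccccc23)cc(OC)c1OC`: 3230 nM

In a functional assay on HT-29 cells (Homo sapiens) for inhibition (on this read-out higher numbers stand for weaker inhibition and lower numbers for stronger inhibition), compound 2 gives 3230 nM, level with compound 1. Compound 3 `COc1cc(/C=C\c2cn(C)c3ccccc23)cc(OC)c1OC` keeps the double bond as drawn in compound 2 and carries one change: methyl in place of hydrogen on an aromatic nitrogen. Among the compounds with values here, the only measured step, no change at the digits printed from compound 1 to compound 2 (within the scatter), concerns the double bond and not this nitrogen, so it offers no direct guide to the size of this change. A small expected step, leaning tentatively toward stronger inhibition, is a 1.6-fold lower number from compound 2 to compound 3 (0.21 log units; within the scatter). The estimate for compound 3 is 2000 nM, with an expected range from 300 nM to 8000 nM.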

Compound 3, half-maximal inhibitory concentration: 3090 nM
Compound 3: middle estimate off by 1.5-fold (0.19 log units), on the low side, within the range that was stated.
By their numbers in this assay, from the lowest: compounds 3, 1 and 2 (each within the scatter of the next).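

In this assay, methyl in place of hydrogen on an aromatic nitrogen comes with a 1.0-fold lower number from compound 2 to compound 3 (0.02 log units; within the scatter), so with the double bond drawn Z, the hydrogen on this nitrogen is not needed to keep this level of inhibition. Within the data shown here, the earlier pair spoke only about the double bond, whereas this step is the first reading at this nitrogen. No measured fact given here accounts for this result.

On these data alone, whether a longer chain, an acetyl group or an amine-bearing chain on this nitrogen would hold the same level remains open. So does whether methyl would behave the same way with the double bond drawn E.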